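Removing the chloro from compound 2: expected potency

The source may hold more compounds than are shown below. What is called first, only, known or untested is meant among the compounds shown, and "the series" means these compounds.

Measured so far:
compound 1, `Cc1ccc(N2CCN(Cn3nc(-c4ccc5c(c4)OCCO5)oc3=S)CC2)c(C)c1`; compound 2, `S=c1oc(-c2ccc3c(c2)OCCO3)nn1CN1CCN(c2ccc(Cl)cc2)CC1`

In a functional assay on SW 1116 cells (Homo sapiens) for antiproliferative activity, read by MTT assay, with a stated time of 48 h (on this read-out lower numbers stand for stronger inhibition and higher numbers for weaker inhibition), compound 1 gives > 50000 nM, a limit of the assay. In this assay compound 2 likewise gives > 50000 nM, a limit of the assay. The step that the two limits leave unreadable from compound 1 to compound 2 is therefore unreadable; both values sit at the limit of > 50000 nM in this assay, at which 2 of the 2 values shown sit. Compound 2 thus stands at the limit, with no number to place it.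

Compound 3, `S=c1oc(-c2ccc3c(c2)OCCO3)nn1CN1CCN(c2ccccc2)CC1`, is not yet measured. It differs from compound 2 by hydrogen in place of chloro on an aromatic carbon. Among the compounds with values here, no measured step bears on this change, and no read number exists for compound 2, so no size or direction can be derived. Compound 3 is expected to stay at or near the limit, estimated at 60000 nM (range 15000 nM to 200000 nM). The step that the limit leaves unreadable from compound 2 to compound 3 is an estimate only.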

Compound 3, half-maximal inhibitory concentration: > 50000 nM
Compound 3: no number, only a limit; the forecaster's own chance of this, stated with the estimate: 85%; the middle value is on the limit's open side.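

No step among compound 1, compound 2 and compound 3 can be read, as all three values are limits: the limit of > 50000 nM in this assay, at which 3 of the 3 values shown sit.

Whether 4-chlorophenyl, phenyl and 2,4-dimethylphenyl differ at all in this assay stays open, with no read number among the compounds shown.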